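Pyridin-4-yl for Pyridin-3-yl: Expected Effect on Cytotoxicity

The compounds below may be only part of what the source reports. "The series", "measured", "known", "first", "only" and "open" are said of these compounds alone.

Compound 1 `O=C(NCc1ccccc1)c1cn(-c2ccccc2)nc1-c1cccnc1`: in a functional assay on HeLa cells (Homo sapiens) for cytotoxicity, read by MTT assay, with a stated time of 48 h (a higher number here means a weaker inhibitor, a lower number a stronger inhibitor), compound 1 gives only the limit > 100000 nM.
Compound 2 `O=C(c1cn(-c2ccccc2)nc1-c1cccnc1)N1CCC(Cc2ccccc2)CC1`: in this assay compound 2 gives 25300 nM.
Compound 3 `O=C(NCc1ccccc1)c1cn(-c2ccccc2)nc1-c1ccncc1`: in this assay compound 3 gives only the limit > 100000 nM.

Compound 3 arises from compound 1 by one change, (pyridin-4-yl in place of pyridin-3-yl on an aromatic carbon). The step it made, a step that the two limits leave unreadable from compound 1 to compound 3, cannot be read because of the limit of > 100000 nM in this assay, at which 2 of the 3 values shown sit. How the core of compound 2 differs from that of compound 1 is not broken down here. Compound 4 `O=C(c1cn(-c2ccccc2)nc1-c1ccncc1)N1CCC(Cc2ccccc2)CC1`, not yet measured, arises from compound 2 by the same change, (pyridin-4-yl in place of pyridin-3-yl on an aromatic carbon). Since the earlier step is unreadable, compound 4 is expected to lie close to compound 2, a step of about a 1.0-fold lower number from compound 2 to compound 4 (0.01 log units; within the scatter). The estimate for compound 4 in this assay is 25000 nM, between 8000 nM and 80000 nM.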

Compound 4, half-maximal inhibitory concentration: 32800 nM
Beside the measured number, compound 4's estimate is 1.3-fold (0.12 log units) below it, within the range that was stated.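

In this assay, putting pyridin-4-yl in place of pyridin-3-yl on the core of compound 2 gives a 1.3-fold higher number from compound 2 to compound 4 (0.11 log units; within the scatter), so on this core the change cannot be told apart from the usual scatter of repeated measurements. The same change on the core of compound 1 cannot be read, because compound 1 and compound 3 each give a limit and not a number: the limit of > 100000 nM in this assay, at which 2 of the 4 values shown sit. This leaves one readable step on one core, which does not show that the change behaves alike on both cores.

The compounds shown leave open how a pyridin-2-yl or a cyclohexyl group would read in that place. They also leave open what the change does on further cores that give a number in this assay.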